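This account rests on a few compounds, and the source may have more. Where it says the series, first, only, none or still open, it means among the compounds named here.

Measured so far in a functional assay on RXF 393 cells (Homo sapiens) for inhibition, read by sulforhodamine B assay, with a stated time of 48 h; a higher number here means a weaker inhibitor of growth, a lower number a stronger inhibitor of growth:

Compound 1, `COc1cc(CNc2nc3cc(N)cc(N)c3nc2-c2ccccc2)cc(OC)c1OC`: 7410 nM
Compound 2, `Nc1cc(N)c2nc(-c3ccccc3)c(NCc3ccc(F)cc3)nc2c1`: 12300 nM
Compound 3, `COc1ccc(Sc2nc3cc(N)cc(N)c3nc2-c2ccccc2)cc1`: 3090 nM

Among these three, compound 3 carries the lowest number in this assay, and both gaps to it lie beyond the scatter: compound 1 sits higher, and compound 2 sits higher still. For the measured compounds named here, the only step between neighbours that differ in a single place is a 4.0-fold lower number from compound 2 to compound 3 (0.60 log units; beyond the scatter), which exchanged (4-methoxyphenyl)sulfanyl for (4-fluorobenzyl)amino on an aromatic carbon.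

Compound 4, `Nc1cc(N)c2nc(-c3ccccc3)c(Oc3ccc(F)cc3)nc2c1`, continues from compound 3 by the change (4-fluorophenoxy in place of (4-methoxyphenyl)sulfanyl on an aromatic carbon). Going by the values given here, the step from compound 2 to compound 3 touches this change only loosely, since it altered the linking atom together with the ring substituent, and no measured pair isolates the oxygen linker or the fluorine in this position. The 4-fluorophenoxy group does share the fluorine of compound 2, whose value in this assay was the highest of the three. On that basis compound 4 is expected to land somewhat above compound 3, with the step of a 1.6-fold higher number from compound 3 to compound 4 (0.21 log units; within the scatter) estimated to stay small. Compound 4 is therefore estimated at 5000 nM in this assay, within a range of 1500 nM to 16000 nM.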

Compound 4, concentration for 50% growth inhibition: 19100 nM
Compound 4: the middle estimate sits 3.8-fold (0.58 log units) below what was measured; measured number outside the range, above it.
By their numbers in this assay, from the lowest: compound 3; then compounds 1, 2 and 4 (each within the scatter of the next, the first and the last beyond it).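

In this assay, the step of a 6.2-fold higher number from compound 3 to compound 4 (0.79 log units; beyond the scatter) shows that this position, on the aromatic carbon next to the ring nitrogen, does not treat all ring-bearing groups alike: the low number of compound 3 does not carry over to 4-fluorophenoxy. The step of a 1.6-fold higher number from compound 2 to compound 4 (0.19 log units; within the scatter) places 4-fluorophenoxy and (4-fluorobenzyl)amino within the scatter of each other, so these numbers do not separate those two groups, and among compounds 2, 3 and 4 only the (4-methoxyphenyl)sulfanyl group of compound 3 stands apart. Nothing measured alongside these numbers offers an explanation for the gap between compound 3 and compound 4.

The change from compound 3 to compound 4 replaces the sulfur link and the methoxy group at once, so the compounds shown leave open which of the two goes with the higher number. From the compounds shown here alone, a 4-methoxyphenoxy or a (4-fluorophenyl)sulfanyl group at this position would pull the two apart, and how a morpholine or a carboxylic acid there would read also remains open.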